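Replacing the nitrile on a pyrazole urea kinase stabiliser

The compounds below may be only part of what the source reports. "The series", "measured", "known", "first", "only" and "open" are said of these compounds alone.

Of the compounds shown here, three sharing one core have been tested in an assay on isolated protein for inhibition of STE20-like serine/threonine-protein kinase (Homo sapiens), read by thermal shift assay, tested at 10 uM; a lower number here means that the compound stabilises the target less, a higher number that the compound stabilises the target more against heat. Compound 1 `CC(C)(C)c1cc(NC(=O)Nc2ccc(Cl)cc2)n(-c2ccc(OC(F)(F)F)cc2)n1` gives 0.2 degrees C. Compound 2 `CC(C)(C)c1cc(NC(=O)Nc2ccc(Cl)cc2)n(-c2ccc(C#N)cc2)n1` gives 1.6 degrees C, and compound 3 `N#Cc1ccc(-n2nc(C3CC3)cc2NC(=O)Nc2ccc(Cl)cc2)cc1` gives 0.7 degrees C, which is within the scatter of compound 2. Compound 2 therefore sits at the top of the three numbers, but only its gap to compound 1 counts: a number 1.4 degrees C higher from compound 1 to compound 2 (beyond the scatter). The other step, a number 0.90 degrees C lower from compound 2 to compound 3 (within the scatter), shows that swapping the group on the shared core made no difference worth the name.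

Compound 4 `CC(C)(C)c1cc(NC(=O)Nc2ccc(Cl)cc2)n(-c2ccc(NC(=O)C3CC3)cc2)n1` is compound 2 with one change: (cyclopropylcarbonyl)amino in place of cyano on an aromatic carbon. Among the compounds with values here, no measured step covers this particular swap. Within the data shown here, the only step at the same position, from compound 1 to compound 2, changed the number by a modest amount, and the step to compound 3, at another position, stayed within the scatter. The new group is larger than the nitrile it replaces and brings a hydrogen-bond donor, so the outcome in this assay is open; a small loss seems as likely as no change. Compound 4 is therefore expected to come in around 0.8 degrees C, somewhere between -0.5 degrees C and 2.2 degrees C, which means an estimated step of a number 0.80 degrees C lower from compound 2 to compound 4 (within the scatter).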

Compound 4, shift of the target's melting temperature: 4.1 degrees C
Beside the measured number, compound 4's estimate is 3.3 degrees C below it; measured number outside the range, above it.
By their numbers in this assay, from the lowest: compounds 1, 3 and 2 (each within the scatter of the next, the first and the last beyond it); then compound 4.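

In this assay, the aromatic carbon para to a large group accepts a far bulkier substituent than the nitrile without any loss: (cyclopropylcarbonyl)amino gives a number 2.5 degrees C higher from compound 2 to compound 4 (beyond the scatter) and so raises the melting temperature shift instead of lowering it. Measured against the trifluoromethoxy compound, the same group gives a number 3.9 degrees C higher from compound 1 to compound 4 (beyond the scatter) and so, across compound 1, compound 2 and compound 4, all three substituents at this one position are told apart by steps beyond the scatter, which shows that this position strongly affects the read-out. Nothing measured here explains why this group raises the number.

Still open, from the compounds shown here alone, is which part of the new group carries the rise, the cyclopropyl ring or the amide linking it to the aromatic ring, and a plain amine or an acetylamino group at this position would help to separate the two. Also open, going by these compounds, is whether cyclopropyl in place of tert-butyl, which gave a number 0.90 degrees C lower from compound 2 to compound 3 (within the scatter) within the nitrile series, would behave the same way with (cyclopropylcarbonyl)amino on the aromatic ring.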